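Compound 4: 3,4-dimethoxyphenyl in place of 3-chlorophenyl

The source may report more compounds than this note shows. Statements on the series, on what has been measured and on what is new or still open speak of the compounds shown alone.

Measured so far in a functional assay on ZR-75-1 cells (Homo sapiens) for inhibition, read by sulforhodamine B assay; on this read-out lower numbers stand for stronger inhibition of growth and higher numbers for weaker inhibition of growth
Compound 1 (`COc1ccc(-c2ccc(-c3ccc(-c4nc5cc(C)ccc5[nH]4)cc3)cc2)cc1OC`) gives 3100 nM
Compound 2 (`Oc1cccc2[nH]c(-c3ccc(-c4ccc(-c5ccc(F)cc5)cc4)cc3)nc12`) gives 6320 nM
Compound 3 (`Oc1cccc2[nH]c(-c3ccc(-c4ccc(-c5cccc(Cl)c5)cc4)cc3)nc12`) gives 2410 nM

On these numbers compound 3 (2410 nM) lies within the scatter of compound 1 and clearly under compound 2. Compound 4 (`COc1ccc(-c2ccc(-c3ccc(-c4nc5c(O)cccc5[nH]4)cc3)cc2)cc1OC`) carries 3,4-dimethoxyphenyl in place of 3-chlorophenyl on an aromatic carbon. Within the data shown here, the one measured step (a 2.6-fold lower number from compound 2 to compound 3 (0.42 log units; beyond the scatter)) is modest and involves other groups, so it bears only loosely on this change. Compound 1 bears more closely, since it carries the same 3,4-dimethoxyphenyl, though its core differs, and its value sits within the scatter of that of compound 3. In this assay no step beyond the scatter is therefore expected (a 1.2-fold higher number from compound 3 to compound 4 (0.08 log units; within the scatter)). Compound 4 is expected at 2900 nM within an estimated range of 1200 nM to 7000 nM on this read-out.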

Compound 4, concentration for 50% growth inhibition: 2110 nM
Compound 4: middle estimate off by 1.4-fold (0.14 log units), on the high side; the measured number falls inside the stated range.
By their numbers in this assay, from the lowest: compounds 4, 3 and 1 (each within the scatter of the next); then compound 2.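

In this assay, the step with 3,4-dimethoxyphenyl in place of 3-chlorophenyl, a 1.1-fold lower number from compound 3 to compound 4 (0.06 log units; within the scatter), shows that this position, para to a large group, accepts a larger ring substituent carrying hydrogen-bond acceptors with no change beyond the scatter. The 4-fluorophenyl compound remains apart, with a 3.0-fold lower number from compound 2 to compound 4 (0.48 log units; beyond the scatter), whereas the core exchange with 3,4-dimethoxyphenyl held constant, a 1.5-fold lower number from compound 1 to compound 4 (0.17 log units; within the scatter), also stays within the scatter. No supporting evidence is available to explain these results. Still open, from the compounds shown here alone, is how an amine or a carboxylic acid on this ring would read, and whether any such group would move growth inhibition beyond the scatter.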